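The source may report more compounds than this note shows. Statements on the series, on what has been measured and on what is new or still open speak of the compounds shown alone.

Within the data shown here, in a functional assay on HCT-116 cells (Homo sapiens) for inhibition, read by colorimetric assay, with a stated time of 3 days (on this read-out higher numbers stand for weaker inhibition and lower numbers for stronger inhibition), compound 1 `COc1ccc(OC)c(NC(=O)CCCCCCNC(=O)C(O)(O)C(F)(F)F)c1` gives 3870 nM, the only actual number in this small set. Compound 2 `C/C(=N\O)C(=O)NCCCCCC(=O)Nc1ccccc1` reports only a limit, > 100000 nM. Compound 3 `O=C(CCCCCCNC(=O)c1cc(=O)c(O)co1)Nc1ccccc1` also reports only a limit, > 100000 nM. Among the measured compounds shown here, compound 1 is therefore the sole numerical reference point, and no measured pair in the set isolates a single structural change.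

Compound 4 `COc1ccccc1NC(=O)CCCCCCNC(=O)C(O)(O)C(F)(F)F` keeps the core of compound 1 and differs in one place: hydrogen in place of methoxy on an aromatic carbon. This puts hydrogen in place of methoxy on an aromatic carbon, meta to a large group and para to a methoxy group. For the measured compounds named here, with no measured step to draw on, the expectation rests on compound 1, at 3870 nM, and on this single change, while the other methoxy group and the rest of the structure stay in place. In this assay, no step beyond the usual scatter is expected, with at most a slight move towards weaker inhibition. The expected step is a 1.2-fold higher number from compound 1 to compound 4 (0.07 log units; within the scatter). Compound 4 is estimated at 4500 nM, with an expected range of 1500 nM to 15000 nM.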

Compound 4, half-maximal inhibitory concentration: 10100 nM
Compound 4: the middle estimate sits 2.2-fold (0.35 log units) below what was measured; measured number inside the range.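

In this assay, putting hydrogen in place of the methoxy group meta to a large group gives a 2.6-fold higher number from compound 1 to compound 4 (0.42 log units; beyond the scatter). Among these compounds, this is the first change in the set confined to one place, and it shows that this aromatic position is not silent: the methoxy group there goes with stronger inhibition, although the step is modest and the other methoxy group and the rest of the structure are unchanged. No measurement shown accounts for this step.

The compounds shown leave open how a hydroxyl group, a methyl group or a chlorine atom at this position would compare with methoxy or hydrogen. They also leave open whether removing the remaining methoxy group, or using a longer chain, would give a step of similar size.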